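The source may report more compounds than this note shows. Statements on the series, on what has been measured and on what is new or still open speak of the compounds shown alone.

compound 1 `COc1ccccc1-n1cc(C(=O)c2cc(OC)c(OC)c(OC)c2)c(-c2ccccc2)c1` – 150 nM
compound 2 `COc1cc(C(=O)c2cn(-c3cccc(Cl)c3)cc2-c2ccccc2)cc(OC)c1OC` – 150 nM

For the measured compounds named here, in a functional assay on MCF7 cells (Homo sapiens) for cytotoxicity, read by MTT assay, with a stated time of 96 h (a lower number here means a stronger inhibitor, a higher number a weaker inhibitor), compound 2 gives 150 nM and stands level with compound 1, the only other compound measured. Compound 3 `COc1cc(C(=O)c2cn(-c3ccc(Cl)cc3)cc2-c2ccccc2)cc(OC)c1OC` differs from compound 2 in one place: 4-chlorophenyl in place of 3-chlorophenyl on an aromatic nitrogen. In words, it carries 4-chlorophenyl in place of 3-chlorophenyl on an aromatic nitrogen. Going by the values given here, one measured step bears on this change, at the same kind of nitrogen: no change at the digits printed from compound 1 to compound 2 (within the scatter), with 3-chlorophenyl in place of 2-methoxyphenyl. That step exchanged one group for a quite different one and the number stayed put, so a step beyond the scatter is not expected here, in either direction. Among the compounds with values here, no measured compound yet carries 4-chlorophenyl, so the range stays wide. The expected result is no change at the digits printed from compound 2 to compound 3 (within the scatter) in this assay when measured. Compound 3 is estimated at 150 nM, within a range of 50 nM to 500 nM.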

Compound 3, half-maximal inhibitory concentration: 140 nM
Estimate against measurement, compound 3: 1.1-fold (0.03 log units) above, and the stated range covers the measured number.
By their numbers in this assay, from the lowest: compounds 3, 1 and 2 (each within the scatter of the next).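

In this assay, the position of the chlorine on the phenyl ring attached to the aromatic nitrogen makes no measurable difference: 4-chlorophenyl in place of 3-chlorophenyl gives a 1.1-fold lower number from compound 2 to compound 3 (0.03 log units; within the scatter). With 4-chlorophenyl in place of 2-methoxyphenyl, the result is a 1.1-fold lower number from compound 1 to compound 3 (0.03 log units; within the scatter), so all three groups shown on this nitrogen read alike. No measurement at hand explains why these numbers stay together.

As far as these compounds go, all three groups are substituted phenyl rings, so it remains open whether the same flat reading would hold for something quite different on this nitrogen, such as a butyl chain, a pyridine ring, or a phenyl ring carrying an amine or a carboxylic acid. From the compounds shown here alone, it also remains open whether changes elsewhere on the shared core would leave the number just as unmoved.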